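Swapping an octyl chain for a fluoronitrophenyl ring

The source may report more compounds than this note shows. Statements on the series, on what has been measured and on what is new or still open speak of the compounds shown alone.

Measured in a functional assay on DU-145 cells (Homo sapiens) for inhibition, read by MTT assay, with a stated time of 24 h; a lower number here means a stronger inhibitor, a higher number a weaker inhibitor:
Compound 1 `CCOC(=O)C1=Cc2ccccc2OC1(OCc1cn(-c2ccc(C)cc2)nn1)C(F)(F)F` gives 30200 nM.
Compound 2 `CCOC(=O)C1=Cc2ccccc2OC1(OCc1cn(CC(=O)Nc2ccccc2F)nn1)C(F)(F)F` gives 33900 nM.
Compound 3 `CCCCCCCCn1cc(COC2(C(F)(F)F)Oc3ccccc3C=C2C(=O)OCC)nn1` reaches only the assay limit, > 150000 nM; this is a limit, not a number.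

Compound 3 therefore stands at the weak end of the three, beyond the scatter from both compound 1 and compound 2, as shown by an at least 4.9-fold higher number from compound 1 to compound 3 (0.69 log units; beyond the scatter) and an at least 4.4-fold higher number from compound 2 to compound 3 (0.64 log units; beyond the scatter). Compound 4 `CCOC(=O)C1=Cc2ccccc2OC1(OCc1cn(-c2ccc(F)c([N+](=O)[O-])c2)nn1)C(F)(F)F` differs from compound 3 by 4-fluoro-3-nitrophenyl in place of octyl on an aromatic nitrogen. The step that bears on this is the reverse of the first of those: a six-membered aromatic ring of carbon only on the aromatic nitrogen returns, in place of the octyl chain. A drop in the number, back toward the region of compound 1, is expected for compound 4, about an at least 4.2-fold lower number from compound 3 to compound 4 (0.63 log units; beyond the scatter), giving an estimated 35000 nM with a range of 15000 nM to 120000 nM.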

Compound 4, half-maximal inhibitory concentration: 13200 nM
Compound 4: the middle estimate sits 2.7-fold (0.42 log units) above what was measured; the measured number lies below the stated range.
By their numbers in this assay, from the lowest: compound 4; then compounds 1 and 2 (each within the scatter of the next). At a limit, above all of these: compound 3.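

Compound 3 stands at a limit of the assay, not at a number, so the first step below is only a bound: the limit of > 150000 nM in this assay, at which 1 of the 4 values shown sits.

On this aromatic nitrogen, 4-fluoro-3-nitrophenyl in place of octyl gives an at least 11-fold lower number from compound 3 to compound 4 (1.05 log units; beyond the scatter). The same ring also gives a 2.3-fold lower number from compound 1 to compound 4 (0.36 log units; beyond the scatter) and a 2.6-fold lower number from compound 2 to compound 4 (0.41 log units; beyond the scatter), so a change at this position can move the number beyond the scatter even when the octyl chain is not involved.

The compounds shown do not separate the part played by the fluorine from that of the nitro group. Going by these compounds, how a phenyl ring carrying an amine or a carboxylic acid would read here remains open.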